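This account rests on a few compounds, and the source may have more. Where it says the series, first, only, none or still open, it means among the compounds named here.

Working notes on the series. The shared core is a benzenesulfonamide carrying an amide on the ring; compound 1 `NS(=O)(=O)c1ccc(CNC(=O)c2ccccc2)cc1` has the amide linked through a methylene, while compound 2 `NS(=O)(=O)c1ccc(NC(=O)c2ccc(F)cc2)cc1` has the amide nitrogen directly on the ring and a fluorine on the benzoyl ring. For the measured compounds named here, in an assay on isolated protein for inhibition of alkaline phosphatase, tissue-nonspecific isozyme (Bos taurus), read by chemiluminescence and spectrophotometry (on this read-out higher numbers stand for weaker inhibition and lower numbers for stronger inhibition), compound 1 gives 918 nM, the lowest of the two numbers so far. In this assay compound 2 gives 25100 nM, a number well beyond the scatter from that of compound 1; as the two compounds differ in two places, the two values can only be set side by side, not read as a single step.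

Compound 3 `NS(=O)(=O)c1ccc(CNC(=O)c2ccc(F)cc2)cc1` is not yet measured. It differs from compound 1 by fluoro in place of hydrogen on an aromatic carbon, para to a large group. Going by the values given here, no measured pair isolates this change, so the expectation rests on the size of the change alone: the step from compound 1 to compound 3 in this assay is expected to be small, a 1.1-fold higher number from compound 1 to compound 3 (0.04 log units; within the scatter), with no direction beyond the scatter. Compound 3 is therefore estimated at 1000 nM, with a range of 400 nM to 2500 nM.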

Compound 3, inhibition constant: 299 nM
Compound 3: the middle estimate sits 3.3-fold (0.52 log units) above what was measured, and the stated range ends above it.
By their numbers in this assay, from the lowest: compound 3; then compound 1; then compound 2.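

In this assay, for the compounds shown here, the phenyl to 4-fluorophenyl change gives a 3.1-fold lower number from compound 1 to compound 3 (0.49 log units; beyond the scatter) and so moves the number beyond the scatter, towards stronger inhibition; this is the first single change read, and it shows that the aromatic carbon para to a large group responds to fluoro in place of hydrogen. Compound 3 also gives the methylene link a comparison at fixed 4-fluorophenyl: compound 3 gives 299 nM while compound 2, which lacks that methylene, gives 25100 nM and so stands at a far higher number. Nothing shown bears on the origin of the fluoro step.

Going by these compounds, whether this response is particular to fluoro remains open, as chloro, methoxy or an amine on the same aromatic carbon would tell that apart, and a longer chain in place of the methylene would extend the reading of the link. Also open, on these data alone, is what the same change does when the amide nitrogen sits directly on the ring, as it does in compound 2.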